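A few compounds are considered here, and "the series" means these few. Any claim that something is new, unique, unknown or untested is made for them only; others in the source may bear on it.

In a functional assay on A2780 cells (Homo sapiens) for cytotoxicity, read by MTT assay, with a stated time of 48 h (a lower number here means a stronger inhibitor, a higher number a weaker inhibitor), compound 1 `CCn1cc(-c2nc3ccccc3[nH]2)c(=O)c2cc(F)c(N3CCNCC3)nc21` gives 4800 nM. Compound 3 `CCn1cc(-c2nc3ccc([N+](=O)[O-])cc3o2)c(=O)c2cc(F)c(N3CCNC(C)C3)c(F)c21` gives 200 nM, so compound 1 holds the higher of the two numbers, and the gap between them lies beyond the scatter. For compound 2 `CCn1cc(-c2nc3ccc([N+](=O)[O-])cc3o2)c(=O)c2cc(F)c(Cl)cc21` the entry reads "not determined" (no result reported), so it adds no number to the comparison.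

Compound 4 `CCn1cc(-c2nc3ccc(N)cc3[nH]2)c(=O)c2cc(F)c(N3CCNCC3)nc21` departs from compound 1 by amino in place of hydrogen on an aromatic carbon, with amino in place of hydrogen on an aromatic carbon. For the measured compounds named here, no pair of measured compounds differs in one place only, so the series offers no direct precedent for this change. Compound 3 at 200 nM also carries a substituent on a six-membered aromatic ring of carbon only, but it differs from compound 1 in other places too, so it gives only weak support. A modest move toward a lower number in this assay is expected, not far past the scatter. The estimated step is a 1.9-fold lower number from compound 1 to compound 4 (0.28 log units; within the scatter). For compound 4 the expected value is 2500 nM, within an estimated range of 700 nM to 9000 nM.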

Compound 4, half-maximal inhibitory concentration: 42300 nM
Estimate against measurement, compound 4: 17-fold (1.23 log units) below, and the stated range ends below it.
By their numbers in this assay, from the lowest: compound 3; then compound 1; then compound 4.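

Amino in place of hydrogen on an aromatic carbon is the first change in the series that can be read in one place, and in this assay it gives an 8.8-fold higher number from compound 1 to compound 4 (0.95 log units; beyond the scatter). The step shows that this carbon of the six-membered aromatic ring of carbon only, part of a fused or bridged system of two rings, is sensitive to substitution, and that amino here moves the compound toward weaker inhibition. Compound 3 could not show this, as it differs from compound 1 in other places too, and no measurement shown here accounts for the step.

Still open, as far as these compounds go, is whether a methoxy group or a carboxylic acid on the same aromatic carbon would move the number in the same direction as amino. Also open, from the compounds shown here alone, is whether amino on another carbon of this ring would give a step of similar size.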